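From (Pyridin-2-yl)carbonyl to Benzyl on the Amine Nitrogen

The compounds below may be only part of what the source reports. "The series", "measured", "known", "first", "only" and "open" are said of these compounds alone.

Compound 1 `COc1ccc(Cn2c(CCc3ccccc3)nnc2[C@H](NC(=O)c2ccccn2)c2c[nH]c3ccccc23)c(OC)c1` was tested in an in vitro assay on LLC-PK1 cells for displacement of a labelled ligand from growth hormone secretagogue receptor type 1 (Homo sapiens) (a higher number here means a weaker inhibitor, a lower number a stronger inhibitor), where compound 1 gives 1.1 nM. Among the two compounds measured so far, compound 1 has the lowest number. The other measured compound, compound 2 `CCc1ccc(Cn2c(CCc3ccccc3)nnc2[C@H](NC(=O)c2ccccn2)c2c[nH]c3ccccc23)cc1`, gives 67 nM in this assay, and the step of a 61-fold higher number from compound 1 to compound 2 (1.78 log units; beyond the scatter) is beyond the scatter. That step concerns the saturated chain carbon bound to an aromatic nitrogen, a different part of the shared core from the one considered next.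

Compound 3 `COc1ccc(Cn2c(CCc3ccccc3)nnc2[C@H](NCc2ccccc2)c2c[nH]c3ccccc23)c(OC)c1` differs from compound 1 in this way: benzyl in place of (pyridin-2-yl)carbonyl on an amine nitrogen. Going by the values given here, no measured step bears on this change, since the single step in hand alters another place in the molecule, so the direction and size of the effect have to be estimated without a direct precedent. A loss of potency of moderate size is expected, with wide uncertainty. Compound 3 is expected to give 15 nM in this assay, with a plausible range from 2 nM to 150 nM. This estimate corresponds to an expected step of a 14-fold higher number from compound 1 to compound 3 (1.13 log units; beyond the scatter).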

Compound 3, half-maximal inhibitory concentration: > 1000 nM
Compound 3: only a limit was reported (the forecaster's own chance of this, stated with the estimate: 2%); middle value at least 66-fold (1.82 log units) away from the limit.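

Until now only the group on the saturated chain carbon bound to an aromatic nitrogen had been varied, and this result shows that the group on the amine nitrogen also has a strong hold on the reading: benzyl in place of (pyridin-2-yl)carbonyl brings an at least 900-fold higher number from compound 1 to compound 3 (2.95 log units; beyond the scatter). For compound 3 the reading in this assay is a limit and not a number: the limit of > 1000 nM in this assay, at which 1 of the 3 values shown sits. Both groups carry a six-membered aromatic ring, so a ring of that size on this nitrogen does not by itself preserve the reading of compound 1, 1.1 nM, even though the leaving group has a carbonyl and 2 hydrogen-bond acceptors while benzyl has 0.

Since the change replaces the carbonyl and the ring nitrogen at once, the compounds shown cannot tell which of the two accounts for the step, and how far compound 3 lies past its limit also stays open. A benzoyl group, which holds the carbonyl on a carbon-only ring, and a (pyridin-2-yl)methyl group, which holds the ring nitrogen without the carbonyl, would pull these two changes apart.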